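Growing the acyl group on the shared core

The compounds below may be only part of what the source reports. "The series", "measured", "known", "first", "only" and "open" are said of these compounds alone.

Of the compounds shown here, two have been measured in an assay on isolated protein for inhibition of aldehyde dehydrogenase 1A1 (Homo sapiens), read by spectrophotometry, tested at 10 uM; a lower number here means less inhibition, a higher number more inhibition at the concentration tested (going by the name of the read-out). Compound 1 `CC(=O)N1CCN(Cc2nc3ccccc3n2Cc2cccc(C)c2)CC1` gives 70.3%, the higher of the two numbers available. Compound 2 `O=C(C1CC1)N1CCN(Cc2nc3ccccc3n2CC2CCCC2)CC1` gives 44.5%, a gap beyond the usual scatter; compound 2 differs from compound 1 in more than one place, so no single step can be read from this pair.

Compound 3 `Cc1cccc(Cn2c(CN3CCN(C(=O)C(C)C)CC3)nc3ccccc32)c1` is not yet measured. It differs from compound 1 in one place: isopropyl in place of methyl on a carbonyl carbon. Cut one bond further out, the change reads acetyl to isopropylcarbonyl.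

Among the compounds with values here, no step between measured compounds touches this position. Compound 2 carries cyclopropyl on the carbonyl carbon together with a different group elsewhere, so its lower value cannot be assigned to the carbonyl substituent alone. The best guide is compound 1 itself, with 70.3% in this assay. A small downward step is expected, a number 10.3 percentage points lower from compound 1 to compound 3 (beyond the scatter), or none beyond the scatter. Compound 3 is estimated at 60%, within a range from 40% to 78%.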

Compound 3, a percentage reported as inhibition, at one concentration (the size of the read-out at that concentration, not a potency): 87.2%
For compound 3 the middle estimate is 27.2 percentage points below the measured one, outside the stated range (above it).
By their numbers in this assay, from the lowest: compound 2; then compound 1; then compound 3.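

Within the data shown here, on the shared core, the acetyl of compound 1 does not mark a ceiling for this position: isopropyl in place of methyl on a carbonyl carbon gives a number 16.9 percentage points higher from compound 1 to compound 3 (beyond the scatter) in this assay and is the only single-place step available. Among these compounds, this is the first direct reading of the carbonyl substituent, and with the larger of these two groups inhibition at the concentration tested rises rather than falls. Among the compounds shown here, nothing measured so far explains the step.

With only methyl and isopropyl compared directly, the step establishes a direction between these two groups and no trend, and steps to compound 2 cannot be read, as it differs from both other compounds in more than one place. Open questions are whether a longer chain such as n-butyl, or a carbonyl substituent carrying an amine, would go on raising the number in this assay, and whether the gain from isopropyl would persist alongside the other group carried by compound 2.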